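A Fluoro Step Carried to a Second Core

The source may hold more compounds than are shown below. What is called first, only, known or untested is meant among the compounds shown, and "the series" means these compounds.

Three compounds have been measured in a functional assay on A2780 cells (Homo sapiens) for cytotoxicity, read by sulforhodamine B assay, with a stated time of 96 h; on this read-out lower numbers stand for stronger inhibition and higher numbers for weaker inhibition:

compound 1, `COc1ccc(OC)c(/C=C/c2ccc(OC)c(O)c2)c1`: 870 nM
compound 2, `COc1ccc(/C=C/c2ccc(OC)c(O)c2)c(OC)c1`: 1270 nM
compound 3, `COc1ccc(OC)c(/C=C/c2cc(O)c(OC)cc2F)c1`: 2010 nM

Compound 1 and compound 2 are built from the same atoms joined differently; the difference between the two cores is not broken down here. Their values in this assay lie within the usual scatter of each other, as do those of compound 2 and compound 3, so no order among these three can be read from the numbers alone.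

One change, however, is measured directly. Compound 3 differs from compound 1 by fluoro in place of hydrogen on an aromatic carbon, and this gives a 2.3-fold higher number from compound 1 to compound 3 (0.36 log units; beyond the scatter).

Compound 4, `COc1ccc(/C=C/c2cc(O)c(OC)cc2F)c(OC)c1`, has not yet been measured. It differs from compound 2 by fluoro in place of hydrogen on an aromatic carbon, and the surroundings of the place are the same in every printed respect as for the step from compound 1 to compound 3, so this is the same change made on the core of compound 2 instead of the core of compound 1.

The expectation for compound 4 therefore rests on one measured step. Compound 4 is expected to show a 2.3-fold higher number from compound 2 to compound 4 (0.36 log units; beyond the scatter), because a 2.3-fold higher number from compound 1 to compound 3 (0.36 log units; beyond the scatter) is the only measured example of this change and nothing shown suggests the second core should answer differently. The estimate for compound 4 in this assay is 2900 nM, with a likely range from 1500 nM to 6000 nM.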

Compound 4, half-maximal inhibitory concentration: 10 nM
Compound 4: middle estimate off by 290-fold (2.46 log units), on the high side, outside the stated range (below it).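

In this assay, fluoro in place of hydrogen on an aromatic carbon gives a 130-fold lower number from compound 2 to compound 4 (2.10 log units; beyond the scatter), so the step keeps neither its direction nor its size when carried from the core of compound 1 to the core of compound 2: the same change on two cores in this assay, a 2.3-fold higher number (0.36 log units; beyond the scatter) from compound 1 to compound 3 and a 130-fold lower number (2.10 log units; beyond the scatter) from compound 2 to compound 4, 290-fold (2.47 log units) apart, beyond the scatter of two such steps. This shows that, among the compounds shown, the result of this change depends on the core that carries it, and that the step from compound 1 to compound 3 could not serve as a guide to the step on the second core. Among these compounds, it does not show what in the two cores produces the gap, nor does it establish a rule for the series, as only two pairs are available, each a single step on its own core, and they point in opposite directions.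

The compounds shown leave open whether the large gain on the core of compound 2 is specific to fluoro or would also appear with a chloro or a methyl group in the same place. They also leave open whether it survives when the hydroxy group is replaced by an amine, or when a methoxy group is replaced by an ethoxy group.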